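A 3-hydroxypropyl chain in place of bromo

This account rests on a few compounds, and the source may have more. Where it says the series, first, only, none or still open, it means among the compounds named here.

Compound 1 `FC(F)(F)c1ccccc1-c1ccc2[nH]c(C3=NOC4(CCCCC4)C3)nc2c1` gives 71%
Compound 2 `FC(F)(F)c1ccccc1-c1cc(Br)c2[nH]c(C3=NOC4(CCCCC4)C3)nc2c1` gives 74%

In an ADME assay on microsomes from liver (Canis lupus familiaris) for metabolic stability, with a stated time of 10 min (a higher number here means that more of the compound is left, a lower number that less of the compound is left), compound 2 gives 74% and stands level with compound 1 within the scatter. Compound 3 `OCCCc1cc(-c2ccccc2C(F)(F)F)cc2nc(C3=NOC4(CCCCC4)C3)[nH]c12` follows from compound 2 through a single change 3-hydroxypropyl in place of bromo on an aromatic carbon with 3-hydroxypropyl in place of bromo on an aromatic carbon. Among the measured compounds shown here, only one measured step bears on this change, namely a number 3 percentage points higher from compound 1 to compound 2 (within the scatter) for bromo in place of hydrogen on an aromatic carbon. For the measured compounds named here, that step stays within the scatter, but no measured compound carries 3-hydroxypropyl, so it offers only weak guidance. A modest fall is therefore expected, with a number 12 percentage points lower from compound 2 to compound 3 (beyond the scatter) as the estimated step and a wide margin either way. The estimate for compound 3 is 62% with an expected range of 42% to 80% for this measurement.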

Compound 3, percent of the compound remaining: 12%
The estimate for compound 3 lay 50 percentage points above the measured number, outside the stated range (below it).
By their numbers in this assay, from the lowest: compound 3; then compounds 1 and 2 (each within the scatter of the next).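

In this assay, the earlier pair showed only that bromo on this aromatic carbon, ortho to a fused ring, leaves the number within the scatter of hydrogen. The 3-hydroxypropyl chain shows that the position does not tolerate every group, giving a number 62 percentage points lower from compound 2 to compound 3 (beyond the scatter). The comparison with the compound carrying hydrogen here points the same way, with a number 59 percentage points lower from compound 1 to compound 3 (beyond the scatter), so the large loss does not depend on bromo as the point of reference.

Nothing available here accounts for this loss. The compounds shown leave open whether it goes with the terminal hydroxyl or with the chain itself, a question that a plain propyl chain, a shorter 2-hydroxyethyl chain or a chain ending in an amine could help to settle.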